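Swapping a bromine for a phenyl on a pyridone amide

A few compounds are considered here, and "the series" means these few. Any claim that something is new, unique, unknown or untested is made for them only; others in the source may bear on it.

Measured compounds:
- compound 1 `Cc1c(Br)cc(C(=O)NC2CCCCCC2)c(=O)n1Cc1ccc(F)cc1` gives 5900 nM in an assay on U-937 cells for inhibition of Fatty-acid amide hydrolase 1 (Homo sapiens), read by scintillation counting, with a stated time of 15 min; on this read-out lower numbers stand for stronger inhibition and higher numbers for weaker inhibition
- compound 2 `Cc1nc(OCc2ccc(F)cc2)c(C(=O)NC2CCCCCC2)cc1-c1ccc(F)cc1` gives > 10000 nM in this assay, which is a limit of the assay rather than a number
- compound 3 `Cc1nc(OCc2ccc(F)cc2)c(C(=O)NC2CCCCCC2)cc1Br` gives > 10000 nM in this assay, again a limit rather than a number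

Compound 1 is the only one of the three with a measured number; the other two sit at the limit, as the line the limit of > 10000 nM in this assay, at which 2 of the 3 values shown sit, records. Because the limits hide both ends, the step that the two limits leave unreadable from compound 2 to compound 3 cannot be read for size or direction.

Compound 4 `Cc1c(-c2ccccc2)cc(C(=O)NC2CCCCCC2)c(=O)n1Cc1ccc(F)cc1` differs from compound 1 by phenyl in place of bromo on an aromatic carbon. Within the data shown here, no measured step matches this change on the core of compound 1; the nearest comparison, from compound 2 to compound 3, involves a different core and is unreadable. Nothing here therefore points to a gain or a loss beyond the scatter.

Compound 4 is estimated at 6000 nM in this assay, with a range from 1500 nM to 20000 nM. The expected step from compound 1 to compound 4 is a 1.0-fold higher number from compound 1 to compound 4 (0.01 log units; within the scatter).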

Compound 4, half-maximal inhibitory concentration: 560 nM
Compound 4: the middle estimate sits 11-fold (1.03 log units) above what was measured; the whole stated range lies above it.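

In this assay, phenyl in place of bromo gives an 11-fold lower number from compound 1 to compound 4 (1.02 log units; beyond the scatter), so on the core of compound 1 this aromatic carbon, ortho to a methyl group, holds a much larger group and the number falls rather than rises. Until now this core had a single measured number, which could say nothing about how much this position matters. The only other pair with a similar swap, on a different core, cannot be read, since both of its compounds sit at the limit: the limit of > 10000 nM in this assay, at which 2 of the 4 values shown sit.

Which feature of the phenyl ring accounts for the gain stays open, and a single swap on one core cannot separate the arrival of the ring from the loss of the bromine. A cyclohexyl ring, a pyridyl ring or a methoxy group on the phenyl ring at this position would help to tell how far the result extends.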